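A New Aryl Group at the Assay Limit

The source may report more compounds than this note shows. Statements on the series, on what has been measured and on what is new or still open speak of the compounds shown alone.

Three compounds share one core and differ in the group on a nitrogen on an aromatic ring. In a functional assay on A549 cells (Homo sapiens) for antiproliferative activity, read by spectrophotometry, with a stated time of 2 days (on this read-out lower numbers stand for stronger inhibition of growth and higher numbers for weaker inhibition of growth), compound 3 (`Cc1cc(C)cc(Nc2ncc(C(F)(F)F)c(N3Cc4cccc(N(C)S(C)(=O)=O)c4C3)n2)c1`) gives > 30000 nM, which is a limit of the assay and not a number. Compound 3 therefore stands at the limit of > 30000 nM in this assay, at which 2 of the 3 values shown sit. For the measured compounds named here, compound 2 (`COc1cc(Nc2ncc(C(F)(F)F)c(N3Cc4cccc(N(C)S(C)(=O)=O)c4C3)n2)cc(OC)c1`), with 3,5-dimethoxyphenyl, gives the only true number, 24800 nM.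

Compound 4 (`Cc1cc(Cl)ccc1Nc1ncc(C(F)(F)F)c(N2Cc3cccc(N(C)S(C)(=O)=O)c3C2)n1`) has 4-chloro-2-methylphenyl in place of the 3,5-dimethylphenyl of compound 3 on a nitrogen on an aromatic ring: 4-chloro-2-methylphenyl in place of 3,5-dimethylphenyl on a nitrogen on an aromatic ring.

Earlier swaps at this same place bear on the change. They gave an at least 1.2-fold lower number from compound 1 to compound 2 (0.08 log units; that floor lies within the scatter) and an at least 1.2-fold higher number from compound 2 to compound 3 (0.08 log units; that floor lies within the scatter), while the remaining swap gave a step that the two limits leave unreadable from compound 1 to compound 3. None of them shows a change beyond the scatter. The closest measured group is the 4-fluoro-2-methylphenyl of compound 1 (`Cc1cc(F)ccc1Nc1ncc(C(F)(F)F)c(N2Cc3cccc(N(C)S(C)(=O)=O)c3C2)n1`). Compound 1 gives > 30000 nM, which is also a limit.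

No step beyond the scatter is therefore expected in this assay, and compound 4 will most likely also reach the limit. The expected change is a number no higher from compound 3 to compound 4 (the limit leaves the size open). For compound 4 the estimated value is 30000 nM, with an expected range from 15000 nM to 60000 nM.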

Compound 4, concentration for 50% growth inhibition: 25500 nM
Estimate against measurement, compound 4: 1.2-fold (0.07 log units) above, and the stated range covers the measured number.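

Compound 4 gives a true number in this assay, so this position now has a second measured value and not only limits, and the step between the two true numbers is a 1.0-fold higher number from compound 2 to compound 4 (0.01 log units; within the scatter). The steps that start from a limit are small as far as they can be read: replacing 3,5-dimethylphenyl with 4-chloro-2-methylphenyl gives an at least 1.1-fold lower number from compound 3 to compound 4 (0.07 log units; that floor lies within the scatter), and putting chloro in place of fluoro on an aromatic carbon gives an at least 1.1-fold lower number from compound 1 to compound 4 (0.07 log units; that floor lies within the scatter). Across these four groups no readable step leaves the scatter, and the values stay crowded at the edge of what the assay can read: the limit of > 30000 nM in this assay, at which 2 of the 4 values shown sit.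

All four compounds carry a substituted phenyl at this place, which leaves open whether a pyridine ring, or a phenyl bearing an amine or a carboxylic acid, would bring the number down to a clearly different level. From the compounds shown here alone, the true distance of compound 1 and compound 3 from compound 4 also stays open, since each of those two compounds is known only as a limit.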